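The compounds below may be only part of what the source reports. "The series", "measured", "known", "first", "only" and "open" are said of these compounds alone.

Three compounds have been measured in a functional assay on NCI-H1650 cells (Homo sapiens) for cytotoxicity, read by MTT assay, with a stated time of 48 h; on this read-out lower numbers stand for stronger inhibition and higher numbers for weaker inhibition:
Compound 1 `CCCCOc1ccc2c(Cl)ccnc2c1` gives 2570 nM.
Compound 2 `Clc1ccnc2cc(OCCCc3ccccc3)ccc12` gives 630 nM.
Compound 3 `Clc1ccnc2cc(OCCc3ccccc3)ccc12` gives 2300 nM.

Compound 1 shows the highest number of the three; compound 3 stands within the scatter of it, while compound 2 lies beyond it, with a 4.1-fold lower number from compound 1 to compound 2 (0.61 log units; beyond the scatter). Compound 4 `C=CCOc1ccc2c(Cl)ccnc2c1` differs from compound 1 by vinyl in place of propyl on a saturated chain carbon bound to an oxygen on an aromatic ring. The measured steps all concern placing a phenyl further out on the chain: a 1.1-fold lower number from compound 1 to compound 3 (0.05 log units; within the scatter) was within the scatter and a 3.7-fold higher number from compound 2 to compound 3 (0.56 log units; beyond the scatter) was beyond it. None of them shortens the chain bound to the oxygen as this change does, so in this assay no step beyond the scatter is expected for compound 4, which is expected to read a 1.2-fold higher number from compound 1 to compound 4 (0.07 log units; within the scatter). Compound 4 is therefore estimated at 3000 nM, with an expected range from 1200 nM to 8000 nM.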

Compound 4, half-maximal inhibitory concentration: 2280 nM
Compound 4: the middle estimate sits 1.3-fold (0.12 log units) above what was measured; the measured number falls inside the stated range.
By their numbers in this assay, from the lowest: compound 2; then compounds 4, 3 and 1 (each within the scatter of the next).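

In this assay, butoxy to allyloxy gives a 1.1-fold lower number from compound 1 to compound 4 (0.05 log units; within the scatter), so at this place on a chain without a phenyl, the vinyl end reads alike with the propyl it replaces. Unlike the phenyl steps, this one brings a double bond outside the aromatic rings into the chain, and that double bond comes with no step beyond the scatter. Nothing available bears on the reason for this result. The compounds shown do not separate the double bond from the change in chain length, which a saturated propoxy chain would address. They also leave open how an amine or a carboxylic acid at the end of the chain would read.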